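The compounds below may be only part of what the source reports. "The series", "measured", "known", "first", "only" and "open" are said of these compounds alone.

Compound 1 `COc1ccc(-c2ccc3c(c2)C(=O)C(=O)N3)cc1`: 6920 nM
Compound 2 `O=C1Nc2ccc(-c3ccc(C(F)(F)F)cc3)cc2C1=O`: > 10000 nM (a limit)

For the measured compounds named here, in a functional assay on K562 cells (Homo sapiens) for antiproliferative activity, read by MTT assay, with a stated time of 48 h (on this read-out higher numbers stand for weaker inhibition and lower numbers for stronger inhibition), compound 1 gives 6920 nM as the only exact number available. The reading for compound 2 of > 10000 nM is a limit of the assay and not a number.

Compound 3 `CCN1C(=O)C(=O)c2cc(-c3ccc(OC)cc3)ccc21` has ethyl in place of hydrogen on an amide-type nitrogen in a ring. Going by the values given here, the one measured step, an at least 1.4-fold higher number from compound 1 to compound 2 (0.15 log units; that floor lies within the scatter), is trifluoromethyl in place of methoxy on an aromatic carbon. Among the compounds with values here, it concerns a different place and its floor lies within the scatter, so no measured step speaks directly to this change.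

With compound 1 at 6920 nM there is more room toward stronger inhibition than toward weaker in this assay, so a modest move in that direction is expected. The expected change is a 2.3-fold lower number from compound 1 to compound 3 (0.36 log units; beyond the scatter) and it remains uncertain. For compound 3 the estimated value is 3000 nM, with an expected range of 600 nM to 10000 nM.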

Compound 3, half-maximal inhibitory concentration: 2200 nM
Compound 3: the middle estimate sits 1.4-fold (0.13 log units) above what was measured; the measured number falls inside the stated range.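

Replacing the amide hydrogen with ethyl gives the only step among these compounds that is a firm number and lies beyond the scatter: in this assay there is a 3.1-fold lower number from compound 1 to compound 3 (0.50 log units; beyond the scatter). This shows that the amide-type nitrogen in the ring can carry a small chain without losing activity on these cells, and that the amide hydrogen of compound 1 is not required for the activity seen there. Nothing available here explains why the number falls with this change.

Going by these compounds, it remains open whether a longer chain such as propyl or butyl, a benzyl group, or a chain ending in an amine on this nitrogen would lower the number further or raise it. On these data alone, it is also open whether ethyl would have a similar effect with trifluoromethyl in place of the methoxy.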